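Replacing bromine with a 2-fluorophenyl group on the shared core

The compounds below may be only part of what the source reports. "The series", "measured", "known", "first", "only" and "open" are said of these compounds alone.

Measured so far:
Compound 1, `Brc1cn2ccnc2c(-c2ccc3ncn(C4CCCCC4)c3c2)n1`: 10%
Compound 2, `COc1ccc(-c2cn3ccnc3c(-c3ccc4ncn(C5CCCCC5)c4c3)n2)cc1`: 83.2%
Compound 3, `Brc1ccc(-c2cn3ccnc3c(-c3ccc4ncn(C5CCCCC5)c4c3)n2)cc1`: 18%

These three compounds share a core and differ in one group on an aromatic carbon. In a functional assay on 786-0 cells (Homo sapiens) for inhibition, read by sulforhodamine B assay, with a stated time of 48 h, tested at 10 uM (a higher number here means more inhibition at the concentration tested (going by the name of the read-out), a lower number less inhibition), compound 1 gives 10%, the low end of the three numbers; compound 3 differs from it only within the scatter, while compound 2 lies far higher.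

Compound 4, `Fc1ccccc1-c1cn2ccnc2c(-c2ccc3ncn(C4CCCCC4)c3c2)n1`, is the next step from compound 1: 2-fluorophenyl in place of bromo on an aromatic carbon. Within the data shown here, two measured steps bear on it, since both also put an aryl ring in place of the bromine. The step of a number 73.2 percentage points higher from compound 1 to compound 2 (beyond the scatter) was large, whereas the step of a number 8 percentage points higher from compound 1 to compound 3 (within the scatter) stayed within the scatter, and the step of a number 65.2 percentage points lower from compound 2 to compound 3 (beyond the scatter) shows how much the substituent on that ring can matter. Among the measured compounds shown here, the 2-fluorophenyl ring carries neither a methoxy nor a bromo group, so no measured step shows its exact effect. In this assay the expected step is a modest rise beyond the scatter, estimated as a number 25 percentage points higher from compound 1 to compound 4 (beyond the scatter). Compound 4 is therefore estimated at 35%, with a range from 8% to 75%.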

Compound 4, a percentage reported as inhibition, at one concentration (the size of the read-out at that concentration, not a potency): 2.94%
For compound 4 the middle estimate is 32.1 percentage points above the measured one; the whole stated range lies above it.
By their numbers in this assay, from the lowest: compounds 4, 1 and 3 (each within the scatter of the next, the first and the last beyond it); then compound 2.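

In this assay, putting an aryl ring at this position does not by itself change the read-out: the step of a number 7.1 percentage points lower from compound 1 to compound 4 (within the scatter) leaves the 2-fluorophenyl compound level with the bromo compound. Among these compounds, the rings also differ from one another, as the step of a number 15.1 percentage points lower from compound 3 to compound 4 (beyond the scatter) is modest and the step of a number 80.3 percentage points lower from compound 2 to compound 4 (beyond the scatter) is large, which leaves the 4-methoxyphenyl group of compound 2 as the only group here tied to high inhibition. No measured evidence explains why these rings read so differently.

The compounds shown leave open whether a 4-fluorophenyl or a 2-methoxyphenyl ring would read like compound 2 or like compound 4. They also leave open how a 4-aminophenyl or 4-hydroxyphenyl ring would behave at this position.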